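A few compounds are considered here, and "the series" means these few. Any claim that something is new, unique, unknown or untested is made for them only; others in the source may bear on it.

Of the compounds shown here, three have been measured so far in a functional assay on HeLa cells (Homo sapiens) for cytotoxicity, read by XTT assay, with a stated time of 72 h (a lower number here means a stronger inhibitor, a higher number a weaker inhibitor), and none of them gives a number. Compound 1 `CC(C)=CCC/C=C(\C)Cc1c(OC/C=C(\C)CCC=C(C)C)cc(O)c2c(=O)cc(-c3ccccc3)oc12` is a flavone-type core carrying a 3,7-dimethylocta-2,6-dien-1-yl chain on a ring carbon and the same chain, through an oxygen, on an aromatic ring. In this assay compound 1 reaches only a limit, > 100000 nM. Compound 2 `CCCCCCCC/C=C\CCCCCCCCOc1cc(O)c(C(C)=O)c(OCCCCCCCC/C=C\CCCCCCCC)c1` likewise reaches only a limit in this assay, > 100000 nM. Compound 3 `CCCCCCCC/C=C\CCCCCCCCOc1cc(O)cc(O)c1C(C)=O` also gives only a limit in this assay, > 100000 nM. Thus compound 1 stands nowhere above or below its companions: all three sit at the limit of > 100000 nM in this assay, at which 3 of the 3 values shown sit, and no step between measured compounds can be drawn from them.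

The next compound, compound 4 `CC(C)=CCC/C=C(\C)Cc1c(O)cc(O)c2c(=O)cc(-c3ccccc3)oc12`, keeps the core of compound 1 and changes one place: hydrogen in place of 3,7-dimethylocta-2,6-dien-1-yl on an oxygen on an aromatic ring. Going by the values given here, the chain on the ring carbon stays; only the one on the oxygen is gone, leaving a hydroxy group in its place.

With every measured value a limit, the data give no direction for such a change. The step is expected to be small, an at least 1.6-fold lower number from compound 1 to compound 4 (0.22 log units; that floor lies within the scatter), and in this assay compound 4 is expected to give 60000 nM, somewhere between 15000 nM and 150000 nM, with a fair chance that it too reports only a limit.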

Compound 4, half-maximal inhibitory concentration: 19000 nM
Compound 4: middle estimate off by 3.2-fold (0.50 log units), on the high side; the range from low to high includes it.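

In this assay, going by these compounds alone, exchanging the 3,7-dimethylocta-2,6-dien-1-yl group on the oxygen for hydrogen, which turns (3,7-dimethylocta-2,6-dien-1-yl)oxy into hydroxy, gives the first step that can be read (an at least 5.2-fold lower number from compound 1 to compound 4 (0.72 log units; beyond the scatter)), and it lies beyond the usual scatter. Within the data shown here, this shows that the place on the core of compound 1 is not silent: with the chain on the ring carbon kept, losing the chain on the oxygen is enough to bring a measurable number, whereas the earlier compounds offered only one shared limit: the limit of > 100000 nM in this assay, at which 3 of the 4 values shown sit. A free hydroxy group does not bring this about everywhere, since compound 2 and compound 3 also differ by a chain on an oxygen against hydrogen, yet both report only limits, so no step can be read for that pair.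

Going by these compounds, what stays open is whether the gain needs the free hydroxy group itself or only the absence of the long chain, which a methyl group, a shorter chain or an amine at this place would help separate. The chain on the ring carbon of compound 4 has not been varied. A comparison with hydrogen at that place has not been measured.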